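The source may hold more compounds than are shown below. What is called first, only, known or untested is meant among the compounds shown, and "the series" means these compounds.

Working notes on the hydrazone series.

Measured so far:
compound 1, `O=C(N/N=C/c1ccc(-c2ccccc2)cc1)c1cnccn1`: 14.4%
compound 2, `O=C(N/N=C/c1ccc(O)cc1)c1cnccn1`: 43.1%
compound 3, `O=C(N/N=C/c1ccc(C(F)(F)F)cc1)c1cnccn1`: 0%

In a functional assay on the whole organism (strain Swiss) for inhibition, with Mus musculus as the target, with stated times of 40 min and 6 h, at a dose of 100 mg/kg by the oral route (a higher number here means more inhibition at the dose given (going by the name of the read-out), a lower number less inhibition), compound 1 gives 14.4%, which is the second highest of the three numbers. Compound 2 gives 43.1% and compound 3 gives 0%. The steps between the three are a number 28.7 percentage points higher from compound 1 to compound 2 (beyond the scatter), a number 14.4 percentage points lower from compound 1 to compound 3 (beyond the scatter) and a number 43.1 percentage points lower from compound 2 to compound 3 (beyond the scatter); all three lie beyond the scatter.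

Compound 4, `O=C(N/N=C/c1ccc(F)cc1)c1cnccn1`, is not yet measured in this assay. It differs from compound 1 in one place: fluoro in place of phenyl on an aromatic carbon. The place is the same aromatic carbon that carries hydroxy in compound 2 and trifluoromethyl in compound 3, so both steps that start from compound 1 bear on the change. They ran in opposite directions, one modest upward, one modest downward. The step to compound 3 also swapped phenyl for a fluorine-bearing group and went down, and the step to compound 2 brought in a group that fluoro does not resemble. On that basis a small downward step is expected for compound 4, one that need not exceed the scatter, as in a number 4.4 percentage points lower from compound 1 to compound 4 (within the scatter). The estimate for compound 4 in this assay is 10%, with a range from 0% to 30%.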

Compound 4, a percentage reported as inhibition, in the whole organism at one dose (the size of the read-out at that dose, not a potency): 24.5%
The estimate for compound 4 lay 14.5 percentage points below the measured number, and the stated range covers the measured number.
By their numbers in this assay, from the lowest: compound 3; then compound 1; then compound 4; then compound 2.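

In this assay, fluorine in the entering group does not fix the direction of the change from phenyl: the swap to fluoro gives a number 10.1 percentage points higher from compound 1 to compound 4 (beyond the scatter), whereas the swap to trifluoromethyl gives a number 14.4 percentage points lower from compound 1 to compound 3 (beyond the scatter). Fluoro and trifluoromethyl are also clearly separated from each other, with a number 24.5 percentage points higher from compound 3 to compound 4 (beyond the scatter), yet fluoro does not reach hydroxy, with a number 18.6 percentage points lower from compound 2 to compound 4 (beyond the scatter), so the four groups on this aromatic carbon give four separate levels and compound 2 remains the highest of the series. The data shown offer no explanation for this order.

The compounds shown leave open where an amine, a carboxylic acid, a methoxy group or chloro on the same aromatic carbon would fall among these four levels, and whether any of them would exceed hydroxy. They also leave open whether fluoro or hydroxy on another carbon of the same ring would give the same order, and whether that order would hold at a different dose.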